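The source may hold more compounds than are shown below. What is called first, only, known or untested is meant among the compounds shown, and "the series" means these compounds.

Measured in a functional assay on A2780 cells (Homo sapiens) for antiproliferative activity, read by MTT assay, with a stated time of 72 h; a lower number here means a stronger inhibitor, a higher number a weaker inhibitor:
- compound 1 `O=C(CCCCCONC(=O)Nc1cnc2ccccc2c1)NO`: 10800 nM
- compound 2 `O=C(CCCCCONC(=O)Nc1cccc2cccnc12)NO`: 3000 nM

Of these two, compound 2 at 3000 nM has the lower number, and its gap to compound 1 lies beyond the usual scatter. Compound 3 `Cc1ccc2cccc(NC(=O)NOCCCCCC(=O)NO)c2n1` has not yet been measured. It differs from compound 2 by methyl in place of hydrogen on an aromatic carbon, next to the ring nitrogen. Within the data shown here, no pair of measured compounds shows what this kind of change does, so the expectation in this assay is cautious: a small shift, none beyond the scatter, with no firm direction. The estimated step is a 1.2-fold lower number from compound 2 to compound 3 (0.08 log units; within the scatter). For compound 3 the expected value is 2500 nM, with an estimated range of 900 nM to 7000 nM.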

Compound 3, half-maximal inhibitory concentration: 4300 nM
The estimate for compound 3 lay 1.7-fold (0.24 log units) below the measured number; low and high end bracket the measured number.
By their numbers in this assay, from the lowest: compounds 2 and 3 (each within the scatter of the next); then compound 1.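

In this assay, methyl in place of hydrogen on an aromatic carbon, next to the ring nitrogen, gives a 1.4-fold higher number from compound 2 to compound 3 (0.16 log units; within the scatter). Among these compounds, this is the first reading of any change at this position: the added carbon leaves compound 3 indistinguishable from compound 2, so a methyl group here is accepted without a measurable loss or gain in antiproliferative activity. No measured data bear on why the position responds in this way.

Open, on these data alone, is whether the same holds for a group other than methyl at this position, such as ethyl, methoxy, an amine or chlorine. Also open, as far as these compounds go, is whether methyl on another aromatic carbon of the shared core would read the same as it does here.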